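Sulfur-linked side group: from vinyl to 4-chlorophenyl

A few compounds are considered here, and "the series" means these few. Any claim that something is new, unique, unknown or untested is made for them only; others in the source may bear on it.

Compound 1 `CCCSc1nc2nc(C)cc(N3CC[C@@H](C)[C@@H](N(C)c4ncnc5[nH]ccc45)C3)n2n1` and compound 2 `C=CCSc1nc2nc(C)cc(N3CC[C@@H](C)[C@@H](N(C)c4ncnc5[nH]ccc45)C3)n2n1` share one core and differ only in the group on a saturated chain carbon bound to a sulfur. In a functional assay on BGC-823 cells (Homo sapiens) for inhibition, read by MTT assay, with a stated time of 72 h (on this read-out higher numbers stand for weaker inhibition and lower numbers for stronger inhibition), compound 1 gives 51200 nM, and compound 2 gives 40900 nM. The step of a 1.3-fold lower number from compound 1 to compound 2 (0.10 log units; within the scatter) shows nothing beyond the scatter. Among the two numbers so far compound 2 holds the lower one, but its only neighbour, compound 1, lies within the scatter of it, so no order between the two can be read.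

Compound 3 `Cc1cc(N2CC[C@@H](C)[C@@H](N(C)c3ncnc4[nH]ccc34)C2)n2nc(SCc3ccc(Cl)cc3)nc2n1` is not yet measured. Relative to compound 2 it carries 4-chlorophenyl in place of vinyl on a saturated chain carbon bound to a sulfur. For the measured compounds named here, the single measured step concerns the same place, yet it exchanged ethyl for vinyl, a far smaller change than the entry of a 4-chlorophenyl, and it stayed within the scatter; it gives little guidance on the size of the coming step in this assay. With no other comparison among these compounds, the expectation for compound 3 is a step of a 1.4-fold lower number from compound 2 to compound 3 (0.13 log units; within the scatter), with a wide margin in either direction. Compound 3 is therefore estimated at 30000 nM, within a range from 8000 nM to 100000 nM.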

Compound 3, half-maximal inhibitory concentration: 26300 nM
For compound 3 the middle estimate is 1.1-fold (0.06 log units) above the measured one; low and high end bracket the measured number.
By their numbers in this assay, from the lowest: compounds 3, 2 and 1 (each within the scatter of the next).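

At the saturated chain carbon bound to a sulfur, the entry of a 4-chlorophenyl, with one six-membered aromatic ring of carbon only, is a far larger exchange than ethyl to vinyl, yet in this assay the result is a 1.6-fold lower number from compound 2 to compound 3 (0.19 log units; within the scatter) and, measured against the ethyl end, a 1.9-fold lower number from compound 1 to compound 3 (0.29 log units; within the scatter) with no step beyond the scatter. This place therefore accepts an aromatic ring carrying chlorine as well as the ethyl and vinyl ends without a readable gain or loss, and the three compounds form one band in which no order can be claimed. Nothing available offers an explanation for this flat result.

From the compounds shown here alone, whether an amine, a carboxylic acid or a longer chain at this same place would move the number beyond the scatter remains open. Also open, going by these compounds, is what a plain phenyl or a 4-methoxyphenyl would give in place of the 4-chlorophenyl, and how far changes elsewhere on the shared core would shift the number in this cell assay.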